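A few compounds are considered here, and "the series" means these few. Any claim that something is new, unique, unknown or untested is made for them only; others in the source may bear on it.

Compound 1 `COc1ccc(Nc2nc(-n3ccnc3C)cs2)cc1`: 1600 nM
Compound 2 `Cc1nccn1-c1csc(Nc2ccc(S(N)(=O)=O)cc2)n1`: 49000 nM
Compound 3 `COc1ccc(Nc2nc(-n3c(C)nc4ccccc43)cs2)cc1`: 25 nM

In a functional assay on RKO cells (Homo sapiens) for cytotoxicity, read by resazurin assay, with a stated time of 72 h (on this read-out lower numbers stand for stronger inhibition and higher numbers for weaker inhibition), compound 1 gives 1600 nM and compound 2 gives 49000 nM; that is a 31-fold higher number from compound 1 to compound 2 (1.49 log units; beyond the scatter), a change described as sulfamoyl in place of methoxy on an aromatic carbon. Compound 3 gives 25 nM and carries a core that differs from that of compound 1 in a way not broken down here. Compound 4 `Cc1nc2ccccc2n1-c1csc(Nc2ccc(S(N)(=O)=O)cc2)n1` has not yet been tested. It is obtained from compound 3 by the same change, (sulfamoyl in place of methoxy on an aromatic carbon), made at the same place. Because the earlier step was a 31-fold higher number from compound 1 to compound 2 (1.49 log units; beyond the scatter), a weakening of similar size is expected for compound 4 in this assay, though the different core leaves room for a smaller or larger effect; the expected step is a 24-fold higher number from compound 3 to compound 4 (1.38 log units; beyond the scatter). Compound 4 is therefore estimated at 600 nM, most likely between 150 nM and 3000 nM.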

Compound 4, half-maximal inhibitory concentration: 45000 nM
For compound 4 the middle estimate is 75-fold (1.88 log units) below the measured one, and the stated range ends below it.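

Sulfamoyl in place of methoxy gives a higher number on both cores in this assay, so the direction of the change carries over, but its size does not: the same change on two cores in this assay, a 31-fold higher number (1.49 log units; beyond the scatter) from compound 1 to compound 2 and a 1800-fold higher number (3.26 log units; beyond the scatter) from compound 3 to compound 4, 59-fold (1.77 log units) apart, beyond the scatter of two such steps

On the core of compound 3 the change gives a 1800-fold higher number from compound 3 to compound 4 (3.26 log units; beyond the scatter) and removes the strong value of the methoxy compound, as compound 2 gives 49000 nM and compound 4 gives 45000 nM. These two pairs show that the size of a step measured on one core cannot simply be transferred to another, but they do not explain the difference or show how a third core would behave.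

As far as these compounds go, it remains open how other groups at this place on the ring, such as an amine or a carboxylic acid, would behave on either core. From the compounds shown here alone, it also remains open whether any of them would keep the strength of compound 3.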